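The source may report more compounds than this note shows. Statements on the series, on what has been measured and on what is new or still open speak of the compounds shown alone.

In an ADME assay on HEK293 cells (Homo sapiens) for cytotoxicity, with a stated time of 72 h (on this read-out higher numbers stand for an effect only at larger amounts of compound and lower numbers for an effect already at smaller amounts), three compounds have been measured and none has yet given a number. Compound 1, `COc1ccc(/C=C/[C@@](C)(/C=C/c2ccc(O)c(/C=C/C(=O)OC(C)(C)C)c2)CCC=C(C)C)cc1`, reads > 36600 nM, which is a limit of the assay. Compound 2, `C=C[C@@](C)(/C=C/c1ccc(Nc2ccc(OC)c(OC)c2)cc1)CCC=C(C)C`, reads > 36600 nM, which is also a limit. Compound 3, `C=C[C@@](C)(/C=C/c1ccc(Nc2ccc(OC)c(F)c2)cc1)CCC=C(C)C`, reads > 36600 nM, again only a limit. The picture so far is therefore (the limit of > 36600 nM in this assay, at which 3 of the 3 values shown sit), and compound 3 has no position beyond it.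

Compound 4, `C=C[C@@](C)(/C=C/c1ccc(Nc2cc(F)c(F)cc2F)cc1)CCC=C(C)C`, has not been measured. It differs from compound 3 by 2,4,5-trifluorophenyl in place of 3-fluoro-4-methoxyphenyl on a nitrogen on an aromatic ring. Among the measured compounds shown here, the one measured step that bears on this is a step that the two limits leave unreadable from compound 2 to compound 3, in which fluoro replaces methoxy on an aromatic carbon of the same group. Its size cannot be read, so it offers no measured effect to carry forward. What the data do show is that compound 2 and compound 3 both remain at the limit. No step beyond the usual scatter is therefore expected in this assay, and no direction is favoured. The expected change is a step that the limit leaves unreadable from compound 3 to compound 4. Compound 4 is estimated at 40000 nM, with an expected range from 18000 nM to 80000 nM.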

Compound 4, half-maximal effective concentration: > 36600 nM
Compound 4 gave a limit, no number; the forecaster's own chance of this, stated with the estimate: 70%; the middle value lies beyond the limit too.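

No new step can be read, since compound 3 and compound 4 both give only a limit in this assay, and the picture stays as it was: the limit of > 36600 nM in this assay, at which 4 of the 4 values shown sit.

The compounds shown leave open how far any of them lies from that limit, and whether any change on the shared core would give a number in this assay.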